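The source may report more compounds than this note shows. Statements on the series, on what has been measured and on what is new or still open speak of the compounds shown alone.

Measured compounds in a functional assay with Rattus norvegicus as the target; a lower number here means that less compound is needed, a higher number that more compound is needed for the effect:
compound 1 `CC1(C)C=C(n2ccccc2=O)c2cc(S(=O)(=O)NCCO)ccc2O1` gives 110 nM
compound 2 `CC1(C)C=C(n2ccccc2=O)c2cc(S(=O)(=O)NCc3ccccc3)ccc2O1` gives 525 nM
compound 3 `CC1(C)C=C(n2ccccc2=O)c2cc(S(=O)(=O)Nc3ccc([N+](=O)[O-])cc3)ccc2O1` gives 2090 nM

Compound 3 stands at the highest number of the three, with a 4.0-fold higher number from compound 2 to compound 3 (0.60 log units; beyond the scatter) and a 19-fold higher number from compound 1 to compound 3 (1.28 log units; beyond the scatter) both beyond the scatter. The next compound, compound 4 `CC1(C)C=C(n2ccccc2=O)c2cc(S(=O)(=O)NC(=O)Nc3ccccc3)ccc2O1`, differs from compound 3 only at the sulfonamide nitrogen: phenylcarbamoyl in place of 4-nitrophenyl on a sulfonamide nitrogen. Going by the values given here, no measured pair mirrors this exchange. Among the compounds with values here, the steps that bear on it are those ending at compound 3: a 19-fold higher number from compound 1 to compound 3 (1.28 log units; beyond the scatter) and a 4.0-fold higher number from compound 2 to compound 3 (0.60 log units; beyond the scatter), both raising the number, so the 4-nitrophenyl group on that nitrogen gave the weakest result of the series. Compound 4 keeps an aromatic ring on that side but presents it as phenylcarbamoyl; the benzyl of compound 2 is the closest comparison, and compound 2 sits below compound 3. The expectation for compound 4 in this assay is therefore a step of a 1.7-fold lower number from compound 3 to compound 4 (0.24 log units; within the scatter), most likely modest and downward, with wide uncertainty. Compound 4 is estimated at 1200 nM, range 400 nM to 4000 nM.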

Compound 4, half-maximal effective concentration: 1410 nM
For compound 4 the middle estimate is 1.2-fold (0.07 log units) below the measured one, and the stated range covers the measured number.
By their numbers in this assay, from the lowest: compound 1; then compound 2; then compounds 4 and 3 (each within the scatter of the next).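

In this assay, phenylcarbamoyl in place of 4-nitrophenyl on a sulfonamide nitrogen gives a 1.5-fold lower number from compound 3 to compound 4 (0.17 log units; within the scatter), so the two groups cannot be told apart here, although phenylcarbamoyl carries a hydrogen-bond donor that 4-nitrophenyl lacks. Compound 4 still separates from the other two, with a 2.7-fold higher number from compound 2 to compound 4 (0.43 log units; beyond the scatter) and a 13-fold higher number from compound 1 to compound 4 (1.11 log units; beyond the scatter), and all three substituents containing an aromatic ring now stand above the 2-hydroxyethyl of compound 1, with no compound shown going against this. No available data explain these differences.

On these data alone, it remains open whether the lower number of compound 1 depends on the hydroxyl group or on the short chain itself. A plain ethyl, a 2-methoxyethyl or a longer 3-hydroxypropyl chain on the sulfonamide nitrogen would bear on this, as would a chain ending in an amine or a carboxylic acid.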